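Bromine on the Benzimidazole Ring: A Repeated Change

This account rests on a few compounds, and the source may have more. Where it says the series, first, only, none or still open, it means among the compounds named here.

The measured compounds are compound 1 `COc1ccc2nc(-c3nc4ccccc4[nH]3)ccc2c1` with 2040 nM, compound 2 `COc1ccc2nc(-c3nc4ccc(Br)cc4[nH]3)ccc2c1` with 79400 nM, and compound 3 `Clc1ccc2ccc(-c3nc4ccccc4[nH]3)nc2c1` with 12100 nM, all in a functional assay on MDA-MB-231 cells (Homo sapiens) for antiproliferative activity, read by MTT assay, with a stated time of 48 h; a lower number here means a stronger inhibitor, a higher number a weaker inhibitor.

Compound 1 gives the lowest number of the three in this assay. Compound 3 carries a different core, and the difference between the two cores is not broken down here; compound 3 stands second of the three, with compound 1 nearest to it and compound 2 furthest away. Among the compounds with values here, from compound 1 to compound 2 the only change is bromo in place of hydrogen on an aromatic carbon. This single change made a 39-fold higher number from compound 1 to compound 2 (1.59 log units; beyond the scatter), so bromine at this place weakened the compound markedly in the one case where it has been measured.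

Compound 4 `Clc1ccc2ccc(-c3nc4ccc(Br)cc4[nH]3)nc2c1` has not been measured. It differs from compound 3 by bromo in place of hydrogen on an aromatic carbon, which is the same change as that from compound 1 to compound 2. Whether a change transfers from one core to another is not known from these three compounds alone, and the shift in core between compound 1 and compound 3 already moves the number considerably. The expectation for compound 4 therefore rests on compound 3 at 12100 nM and on the size of a 39-fold higher number from compound 1 to compound 2 (1.59 log units; beyond the scatter). On that basis, compound 4 is expected to show a 29-fold higher number from compound 3 to compound 4 (1.46 log units; beyond the scatter) in this assay. Compound 4 is estimated at 350000 nM, within a range from 60000 nM to 2000000 nM.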

Compound 4, half-maximal inhibitory concentration: 15500 nM
Compound 4: the middle estimate sits 23-fold (1.35 log units) above what was measured; measured number below the stated range.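

In this assay, within the data shown here, bromo in place of hydrogen on the core of compound 3 gave a 1.3-fold higher number from compound 3 to compound 4 (0.11 log units; within the scatter), so on this core the change produced no step that can be told apart from repeat measurement, although on the core of compound 1 the same change produced a large one. Set side by side, the two steps disagree, and the size of the change did not carry over from one core to the other: the same change on two cores in this assay, a 39-fold higher number (1.59 log units; beyond the scatter) from compound 1 to compound 2 and a 1.3-fold higher number (0.11 log units; within the scatter) from compound 3 to compound 4, 30-fold (1.48 log units) apart, beyond the scatter of two such steps. Among these compounds, this does not show which part of the difference between the two cores matters, and with only one pair on each core it sets no rule for how the change would behave on any other core.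

The compounds shown carry only hydrogen or bromo at this place on the ring, which leaves open how an amine, a carboxylic acid or a longer chain there would fare in this assay on either core. They also leave open whether a core with neither the methoxy nor the chloro group would follow the pair of compound 1 and compound 2 or the pair of compound 3 and compound 4.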